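A Four-Membered Ring Replaces the Piperazine Chain

The source may hold more compounds than are shown below. What is called first, only, known or untested is meant among the compounds shown, and "the series" means these compounds.

Of the compounds shown here, three sharing one core have been tested in an ADME assay on HEp-2 cells (Homo sapiens) for cytotoxicity, read by CCK-8 assay, with a stated time of 5 days; on this read-out higher numbers stand for lower toxicity in this test and lower numbers for higher toxicity in this test. Compound 1 `CNCCNc1cc(N2CCCc3ccc(F)cc3C2)nc2ccc(C)cc12` gives 29000 nM. Compound 2 `Cc1ccc2nc(N3CCCc4ccc(F)cc4C3)cc(NCC(C)(C)N)c2c1` gives 23000 nM. Compound 3 `Cc1ccc2nc(N3CCCc4ccc(F)cc4C3)cc(NCCN3CCNCC3)c2c1` gives 40000 nM. The three differ only in the chain hanging from the nitrogen on the aromatic ring, and none of the changes moved the read-out beyond the scatter: a 1.3-fold lower number from compound 1 to compound 2 (0.10 log units; within the scatter), a 1.4-fold higher number from compound 1 to compound 3 (0.14 log units; within the scatter), and a 1.7-fold higher number from compound 2 to compound 3 (0.24 log units; within the scatter). Compound 3 therefore stands level with the other two, its nearest neighbour being compound 1 and its furthest compound 2, both within the scatter.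

Compound 4 `Cc1ccc2nc(N3CCCc4ccc(F)cc4C3)cc(NC3(CN)COC3)c2c1` has not yet been measured. Against compound 3 the change is 3-(aminomethyl)oxetan-3-yl in place of 2-(piperazin-1-yl)ethyl on a nitrogen on an aromatic ring. All three measured steps bear on this one, since each also swapped the group on that same nitrogen, and each stayed within the scatter. The nearest measured parallel is the step from compound 2 to compound 3, which exchanged an open amine for a piperazine ring without a shift beyond the scatter.

On that basis no step beyond the scatter is expected in this assay. Compound 4 is expected to give 33000 nM, with a range from 14000 nM to 80000 nM. The expected step is a 1.2-fold lower number from compound 3 to compound 4 (0.08 log units; within the scatter), within the scatter.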

Compound 4, half-maximal cytotoxic concentration: 86000 nM
For compound 4 the middle estimate is 2.6-fold (0.42 log units) below the measured one; the whole stated range lies below it.
By their numbers in this assay, from the lowest: compounds 2, 1 and 3 (each within the scatter of the next); then compound 4.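

Until now, the group on this nitrogen had seemed to matter little in this assay, since compounds 1, 2 and 3 all lie within the scatter of one another. Among the compounds shown here, the 3-(aminomethyl)oxetan-3-yl group is the first to separate from the rest, with a 2.2-fold higher number from compound 3 to compound 4 (0.33 log units; beyond the scatter) and a 3.7-fold higher number from compound 2 to compound 4 (0.57 log units; beyond the scatter) and also a 3.0-fold higher number from compound 1 to compound 4 (0.47 log units; beyond the scatter), so this position can shift the read-out, if only modestly, towards lower toxicity in this test. Nothing available explains the shift, which is seen here only as a difference in numbers between compounds.

The change replaces each open chain with a four-membered ring holding one oxygen, so the ring and its oxygen cannot be told apart in these compounds. A 1-(aminomethyl)cyclobutyl group, the same four-membered ring with carbon in place of the oxygen, would help separate the two, and a 3-aminooxetan-3-yl group, with the amine set directly on the ring, would show whether the carbon that links them counts as well.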